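The compounds below may be only part of what the source reports. "The series", "measured", "known", "first", "only" and "open" are said of these compounds alone.

Measured so far in a physicochemical assay for pharmacokinetics, read by LC-MS, in phosphate buffer, at pH 7.4, in the presence of a further agent that is not named here; a lower number here means that the compound disappears faster, a higher number that the compound lasts longer:
compound 1, `C=CC(=O)N1CC(NC(=O)Cn2cc(C(=O)NCc3ccccc3)c3cc(Br)ccc32)C1`: 1.67 h
compound 2, `C=CC(=O)N1CC(NC(=O)Cn2c(C)c(C(=O)N3CCc4c(cccc4OC)C3)c3cc(Cl)cc(C)c32)C1`: 1.67 h

Among the measured compounds shown here, compound 1 and compound 2 share a core and differ in several places at once, so no single-point step has been measured in this assay. In this assay compound 1 gives 1.67 h, and compound 2 gives 1.67 h; the two values are level at the digits shown and lie within the scatter, so no order can be read between them. For the measured compounds named here, compound 1 therefore stands at the same level as the only other measured compound.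

Compound 3, `C=CC(=O)N1CC(NC(=O)Cn2cc(C(=O)N3CCc4c(F)cccc4C3)c3cc(Br)ccc32)C1`, is not yet measured. Relative to compound 1 the change is 5-fluoro-1,2,3,4-tetrahydroisoquinolin-2-yl in place of benzylamino on a carbonyl carbon. Going by the values given here, although it differs from compound 1 in more than one place, compound 2 still gives 1.67 h, so the series so far shows no movement in this assay at all. For compound 3 the step of no change at the digits printed from compound 1 to compound 3 (within the scatter) is expected to be none beyond the scatter. Compound 3 is estimated at 1.67 h, with a range from 0.9 h to 3.1 h.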

Compound 3, half-life: 1.67 h
For compound 3 middle estimate and measured number coincide at the digits printed; low and high end bracket the measured number.
By their numbers in this assay, from the lowest: compounds 1, 2 and 3 (each within the scatter of the next).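

In this assay, among the compounds shown here, 5-fluoro-1,2,3,4-tetrahydroisoquinolin-2-yl in place of benzylamino on a carbonyl carbon gives no change at the digits printed from compound 1 to compound 3 (within the scatter), and this is the only step so far that can be read at a single place. The group that leaves carries 1 hydrogen-bond donor and 8 heavy atoms, the group that enters carries 0 hydrogen-bond donors and 11 heavy atoms, and this exchange leaves no difference that can be read in this assay, so at this place the half-life holds across two quite different amide groups. Nothing at hand bears on why the half-life holds across this exchange.

Still open, from the compounds shown here alone, is whether the fluorine plays any part, which would take the plain 1,2,3,4-tetrahydroisoquinolin-2-yl group on the same carbonyl carbon to tell. Equally open, going by these compounds, is whether this place stays as flat with a piperidine, a primary amine or a longer chain ending in a carboxylic acid, and whether any change to the acryloyl group, the one part held in common here that might be expected to set the half-life, would move the number.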